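The compounds below may be only part of what the source reports. "The series", "measured", "known", "first", "only" and "open" are said of these compounds alone.

Three compounds have been measured in an assay on CHO cells for displacement of a labelled ligand from adenosine receptor A1 (Homo sapiens), read by scintillation counting, with a stated time of 3 h; a higher number here means a weaker inhibitor, a lower number a stronger inhibitor:
compound 1, `Cn1c(-c2ccccc2)nc2c(NC3CCCC3)ncnc21`, 2.8 nM;
compound 2, `Cn1c(-c2ccccc2)nc2c(NC3CCOC3)ncnc21`, 8 nM;
compound 3, `CCCn1c(-c2ccccc2)nc2c(NC3CCCC3)ncnc21`, 10 nM.

Compound 1 gives the lowest number of the three; the nearest is compound 2, separated by a 2.9-fold higher number from compound 1 to compound 2 (0.46 log units; beyond the scatter), and compound 3 lies furthest, with a 3.6-fold higher number from compound 1 to compound 3 (0.55 log units; beyond the scatter). Compound 4, `Cn1c(-c2ccccc2Cl)nc2c(NC3CCCC3)ncnc21`, differs from compound 1 by a single change: chloro in place of hydrogen on an aromatic carbon. Neither measured step touches this part of the molecule: the step to compound 2 puts oxolan-3-yl in place of cyclopentyl, the step to compound 3 puts ethyl in place of hydrogen. There is thus no direct guide, and a change within or only modestly beyond the scatter is expected. Compound 4 is estimated at 4 nM, between 1.5 nM and 12 nM, which would mean a 1.4-fold higher number from compound 1 to compound 4 (0.15 log units; within the scatter).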

Compound 4, inhibition constant: 37 nM
Beside the measured number, compound 4's estimate is 9.3-fold (0.97 log units) below it; the whole stated range lies below it.
By their numbers in this assay, from the lowest: compound 1; then compounds 2 and 3 (each within the scatter of the next); then compound 4.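

In this assay, going from phenyl to 2-chlorophenyl gives a 13-fold higher number from compound 1 to compound 4 (1.12 log units; beyond the scatter), so this aromatic carbon, which neither earlier step touched, responds strongly to a single chloro in place of hydrogen. Going by these compounds alone, this is the only step of the three graded large, the two earlier ones being modest. Nothing at hand accounts for the weakening. From the compounds shown here alone, whether a fluoro or methoxy group on this same carbon would weaken binding as much remains open. So does whether chloro would have the same effect in compound 2 or compound 3.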